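The compounds below may be only part of what the source reports. "The series", "measured", "known", "first", "only" and "open" are said of these compounds alone.

Measured compounds:
compound 1, `O=C1C(=O)N(CCCn2cc(COc3cc(=O)oc4ccccc34)nn2)c2ccc(F)cc21`, giving 75%
compound 2, `O=C1C(=O)N(CCCCn2cc(COc3cc(=O)oc4ccccc34)nn2)c2ccc([N+](=O)[O-])cc21`, giving 53%

Compound 1 stands highest of the two numbers in hand; compound 2 is the nearest, and its number is lower by a gap that lies beyond the usual scatter. Going by the values given here, no single-point step between measured compounds is available, as compound 1 and compound 2 differ in more than one place; their two values show only that compound 2 sits lower than compound 1 in a functional assay on HCT-116 cells (Homo sapiens) for inhibition, read by sulforhodamine B assay, with a stated time of 48 h, tested at 50 uM; on this read-out lower numbers stand for less inhibition of growth and higher numbers for more inhibition of growth at the one concentration tested.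

Compound 3, `O=C1C(=O)N(CCCn2cc(COc3cc(=O)oc4ccccc34)nn2)c2ccc([N+](=O)[O-])cc21`, is the next compound for this assay. It differs from compound 1 as follows: nitro in place of fluoro on an aromatic carbon. Compound 3 also carries the nitro group seen in compound 2, though the two are not otherwise the same.

Among the compounds with values here, no measured step covers this exact change. With compound 2 at 53% as the only nitro-bearing point, a downward step from compound 1 is expected in this assay, of moderate size, likely beyond the scatter yet smaller than the gap between compound 1 and compound 2. For compound 3 the expected value is 60%, with a range from 42% to 78%. This corresponds to an expected step of a number 15 percentage points lower from compound 1 to compound 3 (beyond the scatter).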

Compound 3, percent growth inhibition at one concentration: 60%
Compound 3: middle estimate and measured number agree at the digits printed, within the range that was stated.
By their numbers in this assay, from the lowest: compounds 2 and 3 (each within the scatter of the next); then compound 1.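

In this assay, nitro in place of fluoro on an aromatic carbon of the six-membered aromatic ring of carbon only gives a modest step, a number 15 percentage points lower from compound 1 to compound 3 (beyond the scatter) in the series' first comparison at a single place, so growth inhibition at the one tested concentration responds to the group held at this position. Compound 3 at 60% and compound 2 at 53% lie within the scatter of each other, so with nitro on the ring this assay does not separate the two chain lengths of this pair. Nothing on hand accounts for the drop on going from fluoro to nitro.

From the compounds shown here alone, with only fluoro and nitro in view at this position, the effect of an amine, a methoxy group or a carboxylic acid there remains open, and two groups are too few to define a trend. Also open, going by these compounds, is whether the longer chain of compound 2 would leave the value unchanged with fluoro on the ring, as it does within the scatter with nitro.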